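Taking a Methoxy Group Off a Potent Compound

This account rests on a few compounds, and the source may have more. Where it says the series, first, only, none or still open, it means among the compounds named here.

Going by the values given here, in a functional assay on HT-29 cells (Homo sapiens) for cytotoxicity, read by MTT assay, with a stated time of 72 h (a higher number here means a weaker inhibitor, a lower number a stronger inhibitor), compound 1 `COC(=O)c1sc2cc(OC)ccc2c1Nc1cc(OC)c(OC)c(OC)c1` gives 0.9 nM, the lowest of the three numbers measured so far. Compound 3 `CCOC(=O)c1sc2cc(C)ccc2c1Nc1cc(OC)c(OC)c(OC)c1` comes nearest at 6 nM, and compound 2 `CCOC(=O)c1sc2cccc(C)c2c1Nc1cc(OC)c(OC)c(OC)c1` lies furthest at 3610 nM. Compound 4 `COC(=O)c1sc2ccccc2c1Nc1cc(OC)c(OC)c(OC)c1` has not been measured. It carries hydrogen in place of methoxy on an aromatic carbon of compound 1 (hydrogen in place of methoxy on an aromatic carbon). Among the compounds with values here, no measured pair shows this swap alone, so the expectation is loose. Still, compound 2 at 3610 nM and compound 3 at 6 nM show how far close relatives can spread, so a weakening beyond the scatter is expected in this assay. The expected step is a 110-fold higher number from compound 1 to compound 4 (2.05 log units; beyond the scatter). Compound 4 is estimated at 100 nM, with a range of 8 nM to 1500 nM.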

Compound 4, half-maximal inhibitory concentration: 299 nM
Beside the measured number, compound 4's estimate is 3.0-fold (0.48 log units) below it; the range from low to high includes it.
By their numbers in this assay, from the lowest: compound 1; then compound 3; then compound 4; then compound 2.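

Replacing the methoxy group with hydrogen gives a 330-fold higher number from compound 1 to compound 4 (2.52 log units; beyond the scatter), a large step beyond the scatter. This is the first pair shown that differs in one place only, and it ties much of the low number of compound 1 to the methoxy group at this aromatic carbon, meta to a fused ring and para to a fused ring. No measurement here explains why this swap costs so much. Still open is which part of the methoxy group matters: a hydroxyl, an ethoxy group or an amine on this carbon is not among the compounds shown.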